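Fluoro in place of bromo, with little change expected

A few compounds are considered here, and "the series" means these few. Any claim that something is new, unique, unknown or untested is made for them only; others in the source may bear on it.

Of the compounds shown here, three sharing one core have been measured in an ADME assay on cells (Macrophage) for cytotoxicity, read by MTT assay, with a stated time of 24 h; a lower number here means that less compound is tolerated, a higher number that more compound is tolerated. Compound 1 `O=C(/C=C/c1ccc(Br)cc1)NNC(=O)c1ccc2c(c1)OCCO2` gives 259000 nM, compound 2 `O=C(/C=C/c1cccc([N+](=O)[O-])c1)NNC(=O)c1ccc2c(c1)OCCO2` gives 323000 nM, and compound 3 `COc1ccccc1/C=C/C(=O)NNC(=O)c1ccc2c(c1)OCCO2` gives 312000 nM. Compound 1 lies within the scatter of both of the others, so the three values cannot be put in any order.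

Compound 4 `O=C(/C=C/c1ccc(F)cc1)NNC(=O)c1ccc2c(c1)OCCO2` has not yet been measured, and it differs from compound 1 at a single place: fluoro in place of bromo on an aromatic carbon. The change is fluoro in place of bromo on an aromatic carbon, para to a large group. Within the data shown here, no measured step makes this exact exchange, so the evidence is indirect. Two steps replace the whole 4-bromophenyl group of compound 1 with another substituted phenyl group: a 1.2-fold higher number from compound 1 to compound 2 (0.10 log units; within the scatter) and a 1.2-fold higher number from compound 1 to compound 3 (0.08 log units; within the scatter). The remaining step, a 1.0-fold lower number from compound 2 to compound 3 (0.02 log units; within the scatter), also connects two such groups. All three stay within the scatter, and so no step beyond the scatter is expected here in this assay. The estimated step is a 1.1-fold higher number from compound 1 to compound 4 (0.04 log units; within the scatter), which stays within the scatter. For compound 4 the estimated value is 285000 nM, with an expected range of 190000 nM to 420000 nM.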

Compound 4, half-maximal cytotoxic concentration: 319000 nM
For compound 4 the middle estimate is 1.1-fold (0.05 log units) below the measured one, within the range that was stated.
By their numbers in this assay, from the lowest: compounds 1, 3, 4 and 2 (each within the scatter of the next).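

Among these compounds, compound 4 gives the first direct reading of fluoro in place of bromo on this aromatic carbon, para to a large group, and in this assay the exchange stays within the scatter (a 1.2-fold higher number from compound 1 to compound 4 (0.09 log units; within the scatter)). The 4-fluorophenyl group also cannot be told apart from the two other substituted phenyl groups on the same chain carbon, neither the 2-methoxyphenyl group (a 1.0-fold higher number from compound 3 to compound 4 (0.01 log units; within the scatter)) nor the 3-nitrophenyl group (a 1.0-fold lower number from compound 2 to compound 4 (0.01 log units; within the scatter)), so all four compounds now form a single set within the scatter of one another. No measurement shown offers an explanation for how close these values lie.

The compounds shown leave open whether a group of a different kind on this aromatic carbon, such as an amine or a carboxylic acid, would also stay within the scatter of compound 1. On these data alone, all four share the same double-bonded chain and the same core, so it also remains open whether a longer chain in that part of the structure would shift the number in this assay beyond the scatter.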